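The compounds below may be only part of what the source reports. "The series", "measured", "known", "first", "only" and "open" are said of these compounds alone.

Measured in an assay on cells for binding affinity to vitamin D3 receptor (Homo sapiens), read by fluorescence, tested at 1 uM; on this read-out higher numbers stand for more inhibition at the one concentration tested (going by the name of the read-out) and lower numbers for less inhibition:
compound 1 `CCC(CC)(c1ccc(OCCCCCO)c(C)c1)c1ccc(OCC(O)C(C)(C)C)c(OCC(O)C(C)(C)C)c1` gives 67%
compound 2 `CCC(CC)(c1ccc(OCCCCCCO)c(C)c1)c1ccc(OCC(O)C(C)(C)C)c(OCC(O)C(C)(C)C)c1` gives 52%
compound 3 `CCC(CC)(c1ccc(OCCCC(=O)O)c(C)c1)c1ccc(OCC(O)C(C)(C)C)c(OCC(O)C(C)(C)C)c1` gives 14%

Compound 3 stands lowest of the three in this assay: compound 2 lies nearest, a number 38 percentage points lower from compound 2 to compound 3 (beyond the scatter), and compound 1 furthest, a number 53 percentage points lower from compound 1 to compound 3 (beyond the scatter). Compound 4 `CCC(CC)(c1ccc(OCCCCCCC(=O)O)c(C)c1)c1ccc(OCC(O)C(C)(C)C)c(OCC(O)C(C)(C)C)c1` differs from compound 3 by 3-carboxypropyl in place of carboxy on a saturated chain carbon, three bonds along the chain from an oxygen on an aromatic ring. Two kinds of measured step bear on this. Hydroxymethyl in place of hydroxy, a number 15 percentage points lower from compound 1 to compound 2 (beyond the scatter), was a modest fall. Carboxy in place of 2-hydroxyethyl or 3-hydroxypropyl, a number 53 percentage points lower from compound 1 to compound 3 (beyond the scatter) and a number 38 percentage points lower from compound 2 to compound 3 (beyond the scatter), was a large fall. Compound 4 keeps the carboxy; the step most like the change is a number 15 percentage points lower from compound 1 to compound 2 (beyond the scatter), and a modest step, or none beyond the scatter, is expected, with compound 3 already low, which leaves little room downward. Compound 4 is therefore expected at 18%, range 4% to 40%, the expected step being a number 4 percentage points higher from compound 3 to compound 4 (within the scatter).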

Compound 4, a percentage reported as inhibition, at one concentration (the size of the read-out at that concentration, not a potency): "not active" (no number reported)
Compound 4: no number reported; the estimate stays without a comparison.
By their numbers in this assay, from the lowest: compound 3; then compound 2; then compound 1.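

Among the compounds shown here, compound 4 is reported as "not active" in this assay without a number, so no step from compound 1, compound 2 or compound 3 to compound 4 can be read. No evidence bears on this result.
For the compounds shown here, still open is how the read-out follows the length of carboxy-ending chains, with compound 3 the only such compound carrying a number.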